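This account rests on a few compounds, and the source may have more. Where it says the series, first, only, none or still open, it means among the compounds named here.

Measured compounds:
compound 1 `CC(C)=CCC/C(C)=C/CC1Cc2c(OCC=C(C)C)cc(=O)n(CCCO)c2CC1(C)C`: 15.9%
compound 2 `CC(C)=CCC/C(C)=C/CC1Cc2c(OCCCOc3ccc([N+](=O)[O-])cc3)cc(=O)n(CCCO)c2CC1(C)C`: 9.8%

In a functional assay on PANC-1 cells (Homo sapiens) for inhibition, read by MTT assay, with a stated time of 24 h, tested at 10 uM (on this read-out higher numbers stand for more inhibition at the one concentration tested (going by the name of the read-out) and lower numbers for less inhibition), compound 1 gives 15.9% and compound 2 gives 9.8%. Going by the values given here, compound 1 and compound 2 lie within the scatter of each other, the only measured step being a number 6.1 percentage points lower from compound 1 to compound 2 (within the scatter). Compound 3 `CC(C)=CCC/C(C)=C/CC1Cc2c(OC(=O)Nc3ccc(F)cc3F)cc(=O)n(CCCO)c2CC1(C)C` differs from compound 1 in one place: (2,4-difluorophenyl)carbamoyl in place of 3-methylbut-2-en-1-yl on an oxygen on an aromatic ring. Among the compounds with values here, the single measured step, from compound 1 to compound 2, also alters what hangs from the same oxygen on the aromatic ring, though on a saturated chain carbon rather than on the oxygen itself, and it stayed within the scatter. Within the data shown here, with only this one step to go on, and the shared core left untouched, compound 3 is expected to show no step beyond the scatter, the expected step being a number 1.9 percentage points lower from compound 1 to compound 3 (within the scatter). Compound 3 is therefore estimated at 14%, within a range from 2% to 30%.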

Compound 3, a percentage reported as inhibition, at one concentration (the size of the read-out at that concentration, not a potency): 15.6%
Compound 3: middle estimate off by 1.6 percentage points, on the low side; low and high end bracket the measured number.
By their numbers in this assay, from the lowest: compounds 2, 3 and 1 (each within the scatter of the next).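

In this assay, (2,4-difluorophenyl)carbamoyl in place of 3-methylbut-2-en-1-yl on the oxygen on an aromatic ring gives a number 0.3 percentage points lower from compound 1 to compound 3 (within the scatter). Unlike the earlier step, which altered the group further out along the chain on this oxygen, this change replaces the whole group on the oxygen: a chain with no ring gives way to a group with a six-membered aromatic ring of carbon only, fluorine and a hydrogen-bond donor, and the number still stays within the scatter. No measured evidence is available to explain this result.

The compounds shown leave open whether an amine, a carboxylic acid or a longer chain on this oxygen would give a step beyond the scatter. They also leave open how any of these compounds would behave at other concentrations, as the read-out reports a single one.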